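Replacing a methylphenyl with a nitrophenyl on the shared core

The compounds below may be only part of what the source reports. "The series", "measured", "known", "first", "only" and "open" are said of these compounds alone.

Of the compounds shown here, three built on one shared core have been measured in a functional assay on A549 cells (Homo sapiens) for inhibition, read by CCK-8 assay; a higher number here means a weaker inhibitor, a lower number a stronger inhibitor. Compound 1 `Oc1ccccc1/C=N/c1nnc(SCc2nnc(-c3ccccc3Cl)o2)s1` gives 18100 nM. Compound 2 `Oc1ccccc1/C=N/c1nnc(SCc2nnc(-c3ccc(Cl)cc3)o2)s1` gives 30100 nM. Compound 3 `Cc1ccccc1-c1nnc(CSc2nnc(/N=C/c3ccccc3O)s2)o1` gives 7850 nM, the lowest of the three numbers. The step of a 2.3-fold lower number from compound 1 to compound 3 (0.36 log units; beyond the scatter) and the step of a 3.8-fold lower number from compound 2 to compound 3 (0.58 log units; beyond the scatter) both set compound 3 apart from the two chlorophenyl compounds, whereas a 1.7-fold higher number from compound 1 to compound 2 (0.22 log units; within the scatter) is within the scatter.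

Compound 4 `O=[N+]([O-])c1ccc(-c2nnc(CSc3nnc(/N=C/c4ccccc4O)s3)o2)cc1` has not yet been measured. It differs from compound 3 in one place: 4-nitrophenyl in place of 2-methylphenyl on an aromatic carbon. Among the compounds with values here, two measured steps bear on this change. The step of a 3.8-fold lower number from compound 2 to compound 3 (0.58 log units; beyond the scatter) shows a modest gain when a 2-methylphenyl replaced a 4-chlorophenyl, and a 2.3-fold lower number from compound 1 to compound 3 (0.36 log units; beyond the scatter) shows a modest gain when methyl replaced chloro. Compound 4 removes the 2-methylphenyl again and carries a 4-nitrophenyl instead. Within the data shown here, no compound with a nitro group has been measured; the expectation rests on the chlorophenyl compounds alone. A higher number than that of compound 3 is therefore expected, in the direction of the two chlorophenyl compounds. Compound 4 is expected to give 20000 nM in this assay, with a range from 8000 nM to 50000 nM. This estimate means an expected step of a 2.5-fold higher number from compound 3 to compound 4 (0.41 log units; beyond the scatter).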

Compound 4, half-maximal inhibitory concentration: 4130 nM
Beside the measured number, compound 4's estimate is 4.8-fold (0.69 log units) above it; measured number below the stated range.
By their numbers in this assay, from the lowest: compounds 4 and 3 (each within the scatter of the next); then compounds 1 and 2 (each within the scatter of the next).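

In this assay, this position, an aromatic carbon of a five-membered aromatic ring with 2 nitrogen and 1 oxygen, now proves able to give a low number without the 2-methylphenyl, since the 4-nitrophenyl group cannot be told apart from it (a step of a 1.9-fold lower number from compound 3 to compound 4 (0.28 log units; within the scatter)). The new compound also shows that a group on the far end of the phenyl ring does not by itself go with a high number: nitro in place of chloro gives a clear step (of a 7.3-fold lower number from compound 2 to compound 4 (0.86 log units; beyond the scatter)), and the 4-nitrophenyl also separates from the 2-chlorophenyl (by a 4.4-fold lower number from compound 1 to compound 4 (0.64 log units; beyond the scatter)). Nothing available here explains why the nitro and chloro compounds differ.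

The compounds shown cannot say whether the result belongs to the nitro group itself or to its place on the phenyl ring, as a 2-nitrophenyl or a 4-methylphenyl group at this position would help to separate those two. Nor do they show how far the trend extends to quite different groups on the phenyl ring, such as an amine or a carboxylic acid.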